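Swapping the Amine Group on a Carbonyl Carbon

This account rests on a few compounds, and the source may have more. Where it says the series, first, only, none or still open, it means among the compounds named here.

Within the data shown here, in a functional assay on PC-3 cells (Homo sapiens) for antiproliferative activity, read by MTT assay, with a stated time of 48 h (a lower number here means a stronger inhibitor, a higher number a weaker inhibitor), compound 1 `C=CCN(C)C(=O)c1ccc(C(CC)(CC)c2ccc(OCCC(O)(CC)CC)c(C)c2)n1CC` gives 12800 nM and compound 2 `CCn1c(C(=O)Nc2cccc(C(F)(F)F)c2)ccc1C(CC)(CC)c1ccc(OCCC(O)(CC)CC)c(C)c1` gives 23800 nM, so compound 2 stands within the usual scatter of its only measured neighbour. Compound 3 `CCOC(=O)CN(C)C(=O)c1ccc(C(CC)(CC)c2ccc(OCCC(O)(CC)CC)c(C)c2)n1CC` carries ((ethoxycarbonyl)methyl)(methyl)amino in place of (3-(trifluoromethyl)phenyl)amino on a carbonyl carbon. Among the measured compounds shown here, the one measured step, a 1.9-fold higher number from compound 1 to compound 2 (0.27 log units; within the scatter), changes the group at that same place and stays within the scatter. No step beyond the scatter is therefore expected in this assay. The expected step is a 1.5-fold lower number from compound 2 to compound 3 (0.17 log units; within the scatter). The estimated value for compound 3 is 16000 nM, with an expected range from 7000 nM to 36000 nM.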

Compound 3, half-maximal inhibitory concentration: 7140 nM
Estimate against measurement, compound 3: 2.2-fold (0.35 log units) above, within the range that was stated.
By their numbers in this assay, from the lowest: compounds 3, 1 and 2 (each within the scatter of the next, the first and the last beyond it).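

At this carbonyl carbon, the choice of amine group can shift the number in this assay beyond the scatter: ((ethoxycarbonyl)methyl)(methyl)amino in place of (3-(trifluoromethyl)phenyl)amino gives a 3.3-fold lower number from compound 2 to compound 3 (0.52 log units; beyond the scatter). Ethoxycarbonyl in place of vinyl on the chain attached to the amide-type nitrogen stays within the scatter, with a 1.8-fold lower number from compound 1 to compound 3 (0.25 log units; within the scatter). No measurement available here gives a reason for the larger step. That step removes the aromatic ring and the amide hydrogen together, so their shares cannot be separated. A carboxylic acid in place of the ethyl ester, or a simple dimethylamino group, would test what this position tolerates.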